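Replacing an ester with methylsulfanyl on the urea aryl ring

The source may hold more compounds than are shown below. What is called first, only, known or untested is meant among the compounds shown, and "the series" means these compounds.

Measured in a functional assay on CRL2813 cells (Homo sapiens) for cytotoxicity, read by sulforhodamine B assay, with a stated time of 5 days; a lower number here means a stronger inhibitor, a higher number a weaker inhibitor:
- compound 1, `COC(=O)c1cccc(NC(=O)N[C@H]2CC[C@H](Oc3ccc(F)cc3)CC2)c1`: 9200 nM
- compound 2, `O=C(Nc1cccc(C(F)(F)F)c1)N[C@H]1CCCC[C@@H]1Oc1ccc(C(F)(F)F)cc1`: 3100 nM

Compound 1 stands at the highest number of the two, so it is the weaker inhibitor of the pair; compound 2 sits at a lower number, and the gap between them lies beyond the usual scatter. Compound 3, `CSc1cccc(NC(=O)N[C@H]2CC[C@H](Oc3ccc(F)cc3)CC2)c1`, is not yet measured. It differs from compound 1 in one place: methylsulfanyl in place of methoxycarbonyl on an aromatic carbon. Within the data shown here, no measured pair shows this same change, so there is no step to lean on. Compound 3 is expected to give a number close to that of compound 1, with a small lean toward a lower number, and the step of a 1.7-fold lower number from compound 1 to compound 3 (0.22 log units; within the scatter) is estimated to be small, possibly within the scatter. For compound 3 the estimate in this assay is 5500 nM, with a range from 1500 nM to 20000 nM.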

Compound 3, half-maximal inhibitory concentration: 11100 nM
For compound 3 the middle estimate is 2.0-fold (0.30 log units) below the measured one; the range from low to high includes it.
By their numbers in this assay, from the lowest: compound 2; then compounds 1 and 3 (each within the scatter of the next).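

In this assay, putting methylsulfanyl in place of methoxycarbonyl on this aromatic carbon gives a 1.2-fold higher number from compound 1 to compound 3 (0.08 log units; within the scatter), so the two compounds cannot be told apart. Among these compounds, this is the first comparison in the set that changes only one place, and it shows that the ester, with its carbonyl, can give way to a sulfur-linked group without a reading that stands clear of the scatter. Nothing measured here explains this result.

Going by these compounds, whether an amine, a carboxylic acid or a longer chain on this same aromatic carbon would shift the number beyond the scatter remains open. On these data alone, it is also open whether the swap from methoxycarbonyl to methylsulfanyl would behave the same way on a different core.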